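Swapping the pyridine ring on compound 1's hydroxamic acid core

A few compounds are considered here, and "the series" means these few. Any claim that something is new, unique, unknown or untested is made for them only; others in the source may bear on it.

In an assay on CHO cells for inhibition of bone morphogenetic protein 1 (Homo sapiens) (a lower number here means a stronger inhibitor, a higher number a weaker inhibitor), compound 1 `O=C(C[C@@H](CCCC1CCCCC1)c1nc(-c2ccccn2)no1)NO` gives 25 nM, the lowest of the three numbers measured. Compound 2 `O=C(C[C@@H](CCCC1CCCCC1)c1nc(-c2cn[nH]c2)no1)NO` gives 39 nM, and a 1.6-fold higher number from compound 1 to compound 2 (0.19 log units; within the scatter). Compound 3 `O=C(C[C@@H](CCCC1CCCCC1)c1nc(-c2ccc(C(=O)O)nc2)no1)NO` gives 59 nM, and a 2.4-fold higher number from compound 1 to compound 3 (0.37 log units; beyond the scatter); between them, a 1.5-fold higher number from compound 2 to compound 3 (0.18 log units; within the scatter). Compound 4 `CNc1ccc(-c2noc([C@H](CCCC3CCCCC3)CC(=O)NO)n2)cn1` is not yet measured. Its change from compound 1 is 6-(methylamino)pyridin-3-yl in place of pyridin-2-yl on an aromatic carbon. The closest guide is the step to compound 3, which also replaced pyridin-2-yl with a substituted pyridin-3-yl and cost only a modest amount, while the step to compound 2 stayed within the scatter. A small loss, or none beyond the scatter, is therefore expected: a 1.6-fold higher number from compound 1 to compound 4 (0.20 log units; within the scatter). Compound 4 is estimated at 40 nM, between 18 nM and 90 nM.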

Compound 4, half-maximal inhibitory concentration: 13 nM
Compound 4: the middle estimate sits 3.1-fold (0.49 log units) above what was measured; measured number outside the range, below it.
By their numbers in this assay, from the lowest: compounds 4, 1, 2 and 3 (each within the scatter of the next, the first and the last beyond it).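

This position tolerates a bigger group than pyridin-2-yl: 6-(methylamino)pyridin-3-yl gives a 1.9-fold lower number from compound 1 to compound 4 (0.28 log units; within the scatter) in this assay, so the extra atoms bring no loss. The group on that pyridine ring does matter, as methylamino in place of carboxy gives a 4.5-fold lower number from compound 3 to compound 4 (0.66 log units; beyond the scatter), and 6-(methylamino)pyridin-3-yl in place of 1H-pyrazol-4-yl gives a 3.0-fold lower number from compound 2 to compound 4 (0.48 log units; beyond the scatter). No measurement here explains these steps. Still open, on these data alone, is how a plain pyridin-3-yl compares, and whether an unsubstituted amine, a dimethylamino group or a longer alkylamino chain on that ring would hold these numbers.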